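Replacing an alkyne chain with a methoxyethyl chain

The source may hold more compounds than are shown below. What is called first, only, known or untested is meant among the compounds shown, and "the series" means these compounds.

Of the two compounds measured in an assay on isolated protein for agonist activity at prostaglandin E2 receptor EP2 subtype (Homo sapiens) (on this read-out higher numbers stand for an effect only at larger amounts of compound and lower numbers for an effect already at smaller amounts), compound 2 `CC#CCC1([C@H](O)/C=C/[C@H]2COC(=O)N2CCSc2nc(C(=O)O)cs2)CCC1` gives 21 nM, the highest of the two numbers, while compound 1 `O=C(O)c1csc(SCCN2C(=O)OC[C@@H]2/C=C/[C@@H](O)C2(CCCCF)CCC2)n1` gives 2.9 nM. For the measured compounds named here, the one step on record, a 7.2-fold higher number from compound 1 to compound 2 (0.86 log units; beyond the scatter), swapped a saturated fluorinated chain for the alkyne. Compound 3 `COCCCC1([C@H](O)/C=C/[C@H]2COC(=O)N2CCSc2nc(C(=O)O)cs2)CCC1` carries 2-methoxyethyl in place of prop-1-yn-1-yl on a saturated chain carbon bound to a saturated ring carbon, again a saturated chain with one heteroatom, so the direction of that step is expected to reverse, with a step of about a 3.5-fold lower number from compound 2 to compound 3 (0.54 log units; beyond the scatter) anticipated. Compound 3 is therefore estimated at 6 nM, within a range of 2 nM to 20 nM.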

Compound 3, half-maximal effective concentration: 18 nM
For compound 3 the middle estimate is 3.0-fold (0.48 log units) below the measured one; the range from low to high includes it.
By their numbers in this assay, from the lowest: compound 1; then compounds 3 and 2 (each within the scatter of the next).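

The exchange gives a 1.2-fold lower number from compound 2 to compound 3 (0.07 log units; within the scatter), so on a saturated chain carbon bound to a saturated ring carbon, 2-methoxyethyl and prop-1-yn-1-yl cannot be told apart on this read-out. A saturated chain alone therefore does not match compound 1, as the step with methoxy in place of fluoromethyl shows: a 6.2-fold higher number from compound 1 to compound 3 (0.79 log units; beyond the scatter). Compound 1 stays apart from both other compounds.

From the compounds shown here alone, it remains open whether a hydroxyl or an amine at the chain end would fall with compound 1 or with compounds 2 and 3. No evidence at hand explains the separation of compound 1 from the other two.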